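From Methyl to 4-Chlorophenyl: a Step Expected Small

The source may report more compounds than this note shows. Statements on the series, on what has been measured and on what is new or still open speak of the compounds shown alone.

For the measured compounds named here, compound 2 `CC(O)CCn1nc2c(Br)c(Br)c(Br)c(Br)c2n1` gives 0% in a functional assay on CCRF-CEM cells (Homo sapiens) for antiproliferative activity, read by MTT assay, with a stated time of 48 h, tested at 100 uM (on this read-out higher numbers stand for a weaker effect at the one concentration tested and lower numbers for a stronger effect), the lower of the two numbers measured, with compound 1 `COc1cccc(C(O)CCn2nc3c(Br)c(Br)c(Br)c(Br)c3n2)c1` as its only neighbour at 2%, a gap within the scatter. The change from compound 2 to compound 3 `OC(CCn1nc2c(Br)c(Br)c(Br)c(Br)c2n1)c1ccc(Cl)cc1` is 4-chlorophenyl in place of methyl on a saturated chain carbon bound to an oxygen on a saturated carbon and a saturated chain carbon. Going by the values given here, the one measured step that bears on it is the reverse kind of exchange at the same place: a number 2 percentage points lower from compound 1 to compound 2 (within the scatter). Since replacing an aryl group by methyl there left the read-out unchanged beyond the scatter, putting an aryl group back, now 4-chlorophenyl, is expected to do the same; the expectation is a step of a number 3 percentage points higher from compound 2 to compound 3 (within the scatter), which is no change beyond the scatter. Compound 3 is therefore estimated at 3%, within a range from 0% to 15%.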

Compound 3, a percentage reported as activity, at one concentration (the size of the read-out at that concentration, not a potency): 0%
The estimate for compound 3 lay 3 percentage points above the measured number; the range from low to high includes it.
By their numbers in this assay, from the lowest: compounds 2, 3 and 1 (each within the scatter of the next).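

In this assay, the exchange of methyl for 4-chlorophenyl gave no change at the digits printed from compound 2 to compound 3 (within the scatter), so the forward exchange now reads as the earlier reverse exchange did, with a different aryl group. The exchange between the two aryl groups gave a number 2 percentage points lower from compound 1 to compound 3 (within the scatter), which adds a direct comparison of 4-chlorophenyl with 3-methoxyphenyl and places methyl and both aryl groups within the scatter of one another on this saturated chain carbon. No measurement at hand accounts for this sameness.

As far as these compounds go, whether an amine, a carboxylic acid or a longer chain at this place would move the number remains open. Also open, from the compounds shown here alone, is whether these three compounds would separate at a lower concentration, since a single-concentration read-out gives no potency.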